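Swapping cyclohexyl for isobutyl on a curcumin-like amine

The compounds below may be only part of what the source reports. "The series", "measured", "known", "first", "only" and "open" are said of these compounds alone.

Measured compounds:
- compound 1, `COc1cc(/C=C/C(=O)/C=C(/C=C/c2ccc(OC(C)=O)c(OC)c2)NC2CCCCC2)ccc1OC(C)=O`: in a functional assay on Caco-2 cells (Homo sapiens), read by fluorescence, tested at 10 uM (a higher number here means a weaker effect of the compound at the concentration tested, a lower number a stronger effect), compound 1 gives 62%
- compound 2, `COc1cc(/C=C/C(=O)/C=C(/C=C/c2ccc(OC(C)=O)c(OC)c2)NCC(C)C)ccc1OC(C)=O`: in this assay compound 2 gives 77%
- compound 3, `COc1cc(/C=C/C(=O)/C=C(/C=C/c2ccc(O)c(OC)c2)NC2CCCCC2)ccc1O`: in this assay compound 3 gives 63%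

Compound 4, `COc1cc(/C=C/C(=O)/C=C(/C=C/c2ccc(O)c(OC)c2)NCC(C)C)ccc1O`, has not yet been measured. From compound 1 to compound 2 the change is isobutyl in place of cyclohexyl on an amine nitrogen, and it gave a number 15 percentage points higher from compound 1 to compound 2 (beyond the scatter). From compound 3 to compound 4 the change is isobutyl in place of cyclohexyl on an amine nitrogen, the same change at the same place. The cores of compound 1 and compound 3 differ, but that difference is not broken down here; their values lie within the scatter of each other. Because the same change gave a number 15 percentage points higher from compound 1 to compound 2 (beyond the scatter), a step of similar size is expected here, a number 15 percentage points higher from compound 3 to compound 4 (beyond the scatter). Compound 4 is therefore estimated at 78%, most likely between 68% and 88%.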

Compound 4, a percentage reported as activity, at one concentration (the size of the read-out at that concentration, not a potency): 74%
Estimate against measurement, compound 4: 4 percentage points above; the measured number falls inside the stated range.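

On the core of compound 3, the swap of cyclohexyl for isobutyl on the amine nitrogen in this assay gave a number 11 percentage points higher from compound 3 to compound 4 (beyond the scatter), so here too the isobutyl compound shows the weaker effect. Set beside the earlier step, the change carried over from one core to the other with much the same size: the same change on two cores in this assay, a number 15 percentage points higher (beyond the scatter) from compound 1 to compound 2 and a number 11 percentage points higher (beyond the scatter) from compound 3 to compound 4, 4 percentage points apart, within the scatter of two such steps. This rests on just two cores, so it does not show that the step would hold on a third core, and it does not explain why the swap weakens the effect.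

The compounds shown leave open how other groups on that nitrogen would behave, such as a benzyl group or a longer straight chain. They also leave open whether a ring smaller than cyclohexyl, such as cyclopentyl, would read like cyclohexyl or like isobutyl.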